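The source may report more compounds than this note shows. Statements on the series, on what has been measured and on what is new or still open speak of the compounds shown alone.

Compound 1 `CCC(=O)OCc1ccc2oc(=O)c(C(=O)Oc3cccc(Br)c3)cc2c1`: 40.2%
Compound 2 `CC(C)C(=O)OCc1ccc2oc(=O)c(C(=O)Oc3cccc(Br)c3)cc2c1`: 37.8%

Going by the values given here, in a functional assay on HT-1080 cells (Homo sapiens), read by transwell migration, with a stated time of 24 h, tested at 1 uM (a higher number here means a weaker effect of the compound at the concentration tested, a lower number a stronger effect), compound 2 gives 37.8%, the lowest of the two numbers so far; the nearest is compound 1, and the step of a number 2.4 percentage points lower from compound 1 to compound 2 (within the scatter) is within the scatter, so the two compounds cannot be told apart on this read-out. Compound 3 `NCc1ccc2oc(=O)c(C(=O)Oc3cccc(Br)c3)cc2c1` has not been measured yet. It differs from compound 2 in one place: amino in place of (isopropylcarbonyl)oxy on a saturated chain carbon bound to an aromatic carbon. Among the compounds with values here, only one measured step exists, the one from compound 1 to compound 2, and it alters the chain that carries the (isopropylcarbonyl)oxy group without removing it, whereas in compound 3 that whole group is replaced by amino. The measured step therefore bears on the new one only loosely, and it was itself within the scatter. No direction can be read from the data. Compound 3 is expected to give about 42%, in a wide range from 12% to 78%. That estimate corresponds to an expected step of a number 4.2 percentage points higher from compound 2 to compound 3 (within the scatter).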

Compound 3, a percentage reported as activity, at one concentration (the size of the read-out at that concentration, not a potency): 79.3%
Compound 3: the middle estimate sits 37.3 percentage points below what was measured, and the stated range ends below it.
By their numbers in this assay, from the lowest: compounds 2 and 1 (each within the scatter of the next); then compound 3.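

In this assay the saturated chain carbon bound to an aromatic carbon proves sensitive to the group it carries: with amino in place of (isopropylcarbonyl)oxy the read-out is a number 41.5 percentage points higher from compound 2 to compound 3 (beyond the scatter) and with amino in place of propanoyloxy it is a number 39.1 percentage points higher from compound 1 to compound 3 (beyond the scatter) in a weaker effect at the concentration tested. The earlier change within the acyl chain stayed within the scatter, so only the replacement of the whole group shows that this position can affect the read-out. Nothing available explains why this replacement has so large an effect.

As far as these compounds go, it remains open whether a hydroxy group or an acetamido group on this carbon would give a read-out like that of the two acyloxy compounds or like that of the amine. From the compounds shown here alone, it is also open how a longer acyl chain, such as hexanoyloxy, would behave here.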